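Series notes: the step from compound 1 to compound 4

The source may report more compounds than this note shows. Statements on the series, on what has been measured and on what is new or still open speak of the compounds shown alone.

Measured so far:
- Compound 1 `C/C(=N\NC(=O)COc1cccc2ccccc12)c1ccc(C#N)cc1Br` gives 12.7 ug/mL in an ADME assay on HEL cells (Homo sapiens) for cytotoxicity; a lower number here means that less compound is tolerated, a higher number that more compound is tolerated.
- Compound 2 `COc1ccc(/C=N/NC(=O)COc2cccc3ccccc23)cc1OC` gives 52.6 ug/mL in this assay.
- Compound 3 `O=C(COc1cccc2ccccc12)N/N=C/c1ccccc1Cl` gives 62.7 ug/mL in this assay.

Compound 1 stands lowest of the three numbers. Compound 2 sits at a higher number and compound 3 higher still, and both gaps to compound 1 lie beyond the usual scatter. No two of these compounds differ in only one place, so no single structural step can be counted among them; the three values stand side by side without a step between them.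

Compound 4 `C/C(=N\NC(=O)COc1cccc2ccccc12)c1ccccc1O` has not yet been measured in this assay. It differs from compound 1 in one place:

2-hydroxyphenyl in place of 2-bromo-4-cyanophenyl on a carbon with a double bond to nitrogen

The 2-hydroxyphenyl group that enters is smaller than the 2-bromo-4-cyanophenyl group that leaves, and the shared core is kept.

Because compound 1 gives 12.7 ug/mL while compound 2 gives 52.6 ug/mL and compound 3 gives 62.7 ug/mL, the step of a 2.8-fold higher number from compound 1 to compound 4 (0.44 log units; beyond the scatter) is expected to run upward, beyond the scatter, toward the numbers of the other two compounds. This rests on three values only. Compound 4 is expected to give 35 ug/mL in this assay, within the range 15 ug/mL to 80 ug/mL.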

Compound 4, half-maximal cytotoxic concentration: 4 ug/mL
Beside the measured number, compound 4's estimate is 8.8-fold (0.94 log units) above it; the measured number lies below the stated range.
By their numbers in this assay, from the lowest: compound 4; then compound 1; then compounds 2 and 3 (each within the scatter of the next).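

Among these compounds, this is the first single-place step: in this assay, 2-hydroxyphenyl in place of 2-bromo-4-cyanophenyl on a carbon with a double bond to nitrogen gives a 3.2-fold lower number from compound 1 to compound 4 (0.50 log units; beyond the scatter), so this position can shift the number beyond the scatter. A smaller group at this place therefore does not in itself bring a higher number, at least in this one pair, and compound 4 now marks the low end of the four compounds. No measured data on the compounds explain the direction or size of this step.

The step exchanges the whole group at once, so the parts played by the loss of the bromine, the loss of the nitrile and the entry of the hydroxyl cannot be told apart. From the compounds shown here alone, it also remains open how the number would respond to a 2-aminophenyl or 2-carboxyphenyl group at the same place on the shared core, and therefore whether the low value of compound 4 is specific to the hydroxyl.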